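A few compounds are considered here, and "the series" means these few. Any claim that something is new, unique, unknown or untested is made for them only; others in the source may bear on it.

Measured compounds:
- compound 1 `CCCCC[Se]c1nc([Se]CCCCC)c2ccccc2n1`: > 100000 nM
- compound 2 `[SeH]c1nc([SeH])c2ccccc2n1`: 5980 nM
- compound 3 `CSc1nc(Nc2ccccc2)c2ccccc2n1`: 55800 nM

In a functional assay on HTB-54 cells (Homo sapiens) for cytotoxicity, read by MTT assay, with a stated time of 72 h (on this read-out lower numbers stand for stronger inhibition of growth and higher numbers for weaker inhibition of growth), compound 1 reaches only the upper limit of the assay, > 100000 nM, so no number is known for it; it sits at the limit of > 100000 nM in this assay, at which 1 of the 3 values shown sits. Compound 2 gives 5980 nM and compound 3 gives 55800 nM in this assay, both numbers rather than limits. Compound 4 `CCCCC[Se]c1nc(N)c2ccccc2n1` has not yet been measured. It differs from compound 1 in one place: one nitrogen atom in place of a group of 6 heavy atoms (5 carbon, 1 selenium; no ring), on an aromatic carbon. Going by the values given here, since compound 1 has only a limit, no measured step guides the expectation; the amino-bearing compound 4 is expected to show somewhat stronger inhibition of growth, a step of an at least 2.0-fold lower number from compound 1 to compound 4 (0.30 log units; that floor lies within the scatter). Compound 4 is therefore estimated at 50000 nM, within 8000 nM to 200000 nM.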

Compound 4, concentration for 50% growth inhibition: 34600 nM
Estimate against measurement, compound 4: 1.4-fold (0.16 log units) above; the range from low to high includes it.
By their numbers in this assay, from the lowest: compound 2; then compounds 4 and 3 (each within the scatter of the next). At a limit, above all of these: compound 1.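

Putting an amino group in place of the group of 6 heavy atoms on this aromatic carbon gives, in this assay, an at least 2.8-fold lower number from compound 1 to compound 4 (0.46 log units; beyond the scatter). This shows that the position responds to the change, and that the selenium-bearing chain can go from this place without growth inhibition being lost. Only a floor is known for the size of the step, because compound 1 stands at a limit: the limit of > 100000 nM in this assay, at which 1 of the 4 values shown sits.

The compounds shown leave open whether the gain comes from the amino group itself or from losing the larger group. A hydroxyl group, a methylamine or a shorter selenium-linked chain at this position could separate the two.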